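Adding an Ester to the Aniline Ring of Compound 2

A few compounds are considered here, and "the series" means these few. Any claim that something is new, unique, unknown or untested is made for them only; others in the source may bear on it.

Compound 2 `O=C(O)CCCC(=O)Nc1cc(Nc2ccccc2)ncn1` carries a plain phenyl ring on the shared core. For the measured compounds named here, in an assay for inhibition of Receptor tyrosine-protein kinase erbB-3 variant L858R (Homo sapiens), read by mobility shift assay, with a stated time of 10 min (on this read-out higher numbers stand for weaker inhibition and lower numbers for stronger inhibition), compound 2 gives 183 nM, the only firm number among the measured compounds. Compound 1 `O=C(O)CCCC(=O)Nc1cc(Nc2cccc(Br)c2)ncn1`, which bears a bromo on that ring, reaches only a limit in this assay, > 10000 nM. Going by the values given here, the single recorded step, an at least 54-fold lower number from compound 1 to compound 2 (1.73 log units; beyond the scatter), shows that stripping a substituent from this ring brought a strong gain. Compound 3 `CCOC(=O)c1ccc(Nc2cc(NC(=O)CCCC(=O)O)ncn2)cc1` now differs from compound 2 by ethoxycarbonyl in place of hydrogen on an aromatic carbon. Among the compounds with values here, that one step is the only guide, and it points toward a weaker result when this ring is substituted, so compound 3 is expected to show a 4.4-fold higher number from compound 2 to compound 3 (0.64 log units; beyond the scatter). Compound 3 is estimated at 800 nM, within a range from 150 nM to 5000 nM.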

Compound 3, half-maximal inhibitory concentration: 69 nM
For compound 3 the middle estimate is 12-fold (1.06 log units) above the measured one; the measured number lies below the stated range.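

Compound 3 shows that a substituent on this ring need not cost strength: ethoxycarbonyl, para to a large group, gives a 2.7-fold lower number from compound 2 to compound 3 (0.42 log units; beyond the scatter) in this assay. The earlier step, an at least 54-fold lower number from compound 1 to compound 2 (1.73 log units; beyond the scatter), therefore does not hold for every substituent on this ring, and compound 3 goes against any such rule. Nothing shown gives a measured reason for this gain. Still open, as far as these compounds go, is whether a carboxylic acid or an amine at this place would match the ester, and whether a longer chain on the ester would keep the gain.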